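A few compounds are considered here, and "the series" means these few. Any claim that something is new, unique, unknown or untested is made for them only; others in the source may bear on it.

In an ADME assay on microsomes from liver (Homo sapiens) for metabolic stability, read by LC-MS, using NADPH, with a stated time of 45 min (on this read-out lower numbers stand for a shorter-lived compound and higher numbers for a longer-lived compound), three compounds sharing one core have been measured: compound 1 (`CC[C@@H]1C[C@H](C)CC/C=C\[C@@H]2C[C@@]2(C(=O)NS(=O)(=O)C2CC2)NC(=O)[C@@H]2C[C@@H](Oc3ncc(OC)c4ccccc34)CN2C(=O)[C@H]1NC(=O)OC(C)(C)C(F)(F)F`) gives 0.628 h, compound 2 (`CC[C@@H]1C[C@H](C)CC/C=C\[C@@H]2C[C@@]2(C(=O)NS(=O)(=O)C2(C)CC2)NC(=O)[C@@H]2C[C@@H](Oc3ncc(OC)c4ccccc34)CN2C(=O)[C@H]1NC(=O)OC(C)(C)C(F)(F)F`) gives 0.383 h, and compound 3 (`CC[C@@H]1C[C@H](C)CC/C=C\[C@@H]2C[C@@]2(C(=O)NS(=O)(=O)C2(C)CC2)NC(=O)[C@@H]2C[C@@H](Oc3ncc(OC)c4ccc(F)cc34)CN2C(=O)[C@H]1NC(=O)OC(C)(C)C(F)(F)F`) gives 0.717 h. Compound 2 stands within the scatter of both others, with a 1.6-fold lower number from compound 1 to compound 2 (0.21 log units; within the scatter) and a 1.9-fold higher number from compound 2 to compound 3 (0.27 log units; within the scatter).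

Compound 4 (`CC[C@@H]1C[C@H](C)CC/C=C\[C@@H]2C[C@@]2(C(=O)NS(=O)(=O)C2(C)CC2)NC(=O)[C@@H]2C[C@@H](Oc3nccc4cc(O)c(F)cc34)CN2C(=O)[C@H]1NC(=O)OC(C)(C)C(F)(F)F`) has not yet been measured. It carries 7-fluoro-6-hydroxyisoquinolin-1-yl in place of 4-methoxyisoquinolin-1-yl on an oxygen on a saturated carbon. For the measured compounds named here, only one measured step touches this group, fluoro in place of hydrogen on an aromatic carbon, and it gave a 1.9-fold higher number from compound 2 to compound 3 (0.27 log units; within the scatter). The methyl step on a saturated ring carbon lies in another part of the structure. Going by the values given here, no measured compound shows what removing the methoxy group or adding a hydroxy group does, so the guidance is thin. As far as these compounds go, no change beyond the scatter is therefore expected in this assay, and the direction stays open. The estimated change is a 1.3-fold higher number from compound 2 to compound 4 (0.12 log units; within the scatter). For compound 4 the expected half-life is 0.5 h, with an estimated range from 0.2 h to 1.2 h.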

Compound 4, half-life: 0.617 h
For compound 4 the middle estimate is 1.2-fold (0.09 log units) below the measured one, and the stated range covers the measured number.
By their numbers in this assay, from the lowest: compounds 2, 4, 1 and 3 (each within the scatter of the next).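

In this assay, 7-fluoro-6-hydroxyisoquinolin-1-yl in place of 4-methoxyisoquinolin-1-yl gives a 1.6-fold higher number from compound 2 to compound 4 (0.21 log units; within the scatter), which shows that the whole group on an oxygen on a saturated carbon can be exchanged without a step beyond the scatter. The earlier compounds had shown only a single fluoro in place of hydrogen on an aromatic carbon of this group, whereas here the methoxy group is gone and the entering group carries a hydrogen-bond donor that the leaving group lacks. Nothing in the data gives a cause for this result.

The separate contributions of losing the methoxy group, adding the hydroxy group and adding the fluoro group remain unresolved in this single step. As far as these compounds go, it also remains open whether an amine or a carboxylic acid in place of the hydroxy group would give a step beyond the scatter.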